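Trading a benzyl amide for an anilide

A few compounds are considered here, and "the series" means these few. Any claim that something is new, unique, unknown or untested is made for them only; others in the source may bear on it.

Compound 1, `COc1cccc(NC(=O)/C=C/c2coc3cc(OC)ccc3c2=O)c1`, gives 19200 nM in a functional assay on HeLa cells (Homo sapiens) for inhibition, read by MTT assay, with a stated time of 48 h; a higher number here means a weaker inhibitor, a lower number a stronger inhibitor.
Compound 2, `COc1ccc2c(=O)c(/C=C/C(=O)NCc3ccc(F)cc3)coc2c1`, gives only a limit, > 100000 nM.
Compound 3, `O=C(/C=C/c1coc2cc(O)ccc2c1=O)NCc1ccc(F)cc1`, gives only a limit, > 100000 nM.

Compound 2 therefore stands at the assay limit (the limit of > 100000 nM in this assay, at which 2 of the 3 values shown sit), its potency unresolved. Compound 3 sits at that same limit. Compound 4, `COc1ccc2c(=O)c(/C=C/C(=O)Nc3ccc(F)cc3)coc2c1`, differs from compound 2 by 4-fluorophenyl in place of 4-fluorobenzyl on an amide-type nitrogen. Among the compounds with values here, one measured step bears on this change and runs the opposite way: an at least 5.2-fold higher number from compound 1 to compound 2 (0.71 log units; beyond the scatter), an anilide giving way to a benzyl amide. Compound 4 restores an anilide, so a gain of roughly that size is expected, with compound 1 at 19200 nM as the only anchor. The estimate for compound 4 is 30000 nM, within 10000 nM to 150000 nM. The expected step is an at least 3.3-fold lower number from compound 2 to compound 4 (0.52 log units; beyond the scatter).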

Compound 4, half-maximal inhibitory concentration: 9680 nM
Beside the measured number, compound 4's estimate is 3.1-fold (0.49 log units) above it; the measured number lies below the stated range.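

Replacing 4-fluorobenzyl with 4-fluorophenyl on the amide-type nitrogen, with the rest of the molecule unchanged, gives a clear gain in this assay: an at least 10-fold lower number from compound 2 to compound 4 (1.01 log units; beyond the scatter). The aryl group itself makes no readable difference, as 4-fluorophenyl and 3-methoxyphenyl stand within the scatter: a 2.0-fold lower number from compound 1 to compound 4 (0.30 log units; within the scatter). The full size of the first step stays unknown because compound 2 gives only a limit: the limit of > 100000 nM in this assay, at which 2 of the 4 values shown sit.

As far as these compounds go, it remains open whether a phenethyl group or a pyridyl ring on that nitrogen would hold this level. Also open, from the compounds shown here alone, is whether a hydroxyl on the shared core in place of the methoxy would change the anilide.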